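A few compounds are considered here, and "the series" means these few. Any claim that something is new, unique, unknown or untested is made for them only; others in the source may bear on it.

In a toxicity assay on the whole organism (strain Icem-CET (SPF Caw)) for cytotoxicity, with Mus musculus as the target (on this read-out lower numbers stand for an effect already at smaller amounts and higher numbers for an effect only at larger amounts of compound), compound 1, `C#CCNC(=O)/C(C)=C(\C)c1ccc(Br)cc1`, gives 500 mg/kg. In this assay compound 2, `C=CCNC(=O)/C(C)=C(\C)c1ccc(Br)cc1`, gives 500 mg/kg. In this assay compound 3, `C=CCNC(=O)/C(C)=C(\C)c1cc(OC)c(OC)c(OC)c1`, gives 280 mg/kg.

Compound 1 and compound 2 share the same core and differ in one place only: ethynyl in place of vinyl on a saturated chain carbon bound to an amide-type nitrogen. In this assay this change produced no change at the digits printed from compound 2 to compound 1 (within the scatter). Compound 3 is built on a different core; the difference between the two cores is not broken down here. The number for compound 3 lies within the usual scatter of those for compound 1 and compound 2, so no order among the three can be read from these data.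

Compound 4, `C#CCNC(=O)/C(C)=C(\C)c1cc(OC)c(OC)c(OC)c1`, has not yet been measured. It relates to compound 3 exactly as compound 1 relates to compound 2, the difference being (ethynyl in place of vinyl on a saturated chain carbon bound to an amide-type nitrogen), the same change at the same place. In this assay the expected step is no change at the digits printed from compound 3 to compound 4 (within the scatter), resting on no change at the digits printed from compound 2 to compound 1 (within the scatter), where the same change left the number unchanged. Compound 4 is therefore estimated at 280 mg/kg, with a likely range from 150 mg/kg to 520 mg/kg.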

Compound 4, dose for half-maximal effect: 300 mg/kg
Compound 4: middle estimate off by 1.1-fold (0.03 log units), on the low side; low and high end bracket the measured number.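

In this assay, replacing vinyl with ethynyl on a saturated chain carbon bound to an amide-type nitrogen, which turns allyl into propargyl, gives a 1.1-fold higher number from compound 3 to compound 4 (0.03 log units; within the scatter). Set beside the same change on the core of compound 1, the two results agree: the same change on two cores in this assay, no change at the digits printed (within the scatter) from compound 2 to compound 1 and a 1.1-fold higher number (0.03 log units; within the scatter) from compound 3 to compound 4, 1.1-fold (0.03 log units) apart, within the scatter of two such steps. This shows that, on these two cores, the swap can be carried from one to the other without moving the number beyond the usual scatter, so the earlier step was a fair guide here; it does not show that this would hold on any further core, and it says nothing about why the number stays put.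

The compounds shown leave open what happens when something other than these two small carbon groups sits at this place, such as a longer chain like butyl, an amine or a carboxylic acid. They also leave open whether a third core would give the same result for the swap from allyl to propargyl.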